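The compounds below may be only part of what the source reports. "The series", "measured", "known", "first", "only" and "open" are said of these compounds alone.

The series shares one core; compound 1 `Cc1noc(C)c1-c1cnc(N)c(Oc2ccc(C(=O)NC3CC3)cc2)n1`, compound 2 `Cc1noc(C)c1-c1cnc(N)c(Oc2ccc(C(=O)NC3CCCCC3)cc2)n1` and compound 3 `Cc1noc(C)c1-c1cnc(N)c(Oc2ccc(C(=O)Nc3ccccc3Cl)cc2)n1` differ only in the group on the amide-type nitrogen. In a functional assay on U-87MG ATCC cells for inhibition, with U-87 MG (Homo sapiens) as the target, read by MTT assay, with a stated time of 72 h (on this read-out higher numbers stand for weaker inhibition and lower numbers for stronger inhibition), compound 1 gives 43300 nM, compound 2 gives 40400 nM and compound 3 gives 60500 nM, the highest of the three numbers, though a 1.4-fold higher number from compound 1 to compound 3 (0.15 log units; within the scatter) and a 1.5-fold higher number from compound 2 to compound 3 (0.18 log units; within the scatter) both sit within the scatter, as does a 1.1-fold lower number from compound 1 to compound 2 (0.03 log units; within the scatter). Compound 4 `Cc1noc(C)c1-c1cnc(N)c(Oc2ccc(C(=O)Nc3ccc(Cl)cc3)cc2)n1` is not yet measured; the change is 4-chlorophenyl in place of 2-chlorophenyl on an amide-type nitrogen, the same atoms joined differently. Going by the values given here, no measured step moves the chlorine around the phenyl group, and the three steps on that nitrogen all stayed within the scatter, so no step beyond the scatter is expected in this assay, estimated as a 1.1-fold lower number from compound 3 to compound 4 (0.04 log units; within the scatter). Compound 4 is therefore expected to give 55000 nM, with a range of 25000 nM to 120000 nM.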

Compound 4, half-maximal inhibitory concentration: 15500 nM
Estimate against measurement, compound 4: 3.5-fold (0.55 log units) above; the measured number lies below the stated range.
By their numbers in this assay, from the lowest: compound 4; then compounds 2, 1 and 3 (each within the scatter of the next).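

In this assay, going by these compounds alone, where the three earlier groups on the amide-type nitrogen stayed within the scatter, moving the chlorine alone gives the first step beyond it: a 3.9-fold lower number from compound 3 to compound 4 (0.59 log units; beyond the scatter) for 4-chlorophenyl in place of 2-chlorophenyl. The 4-chlorophenyl group also separates from the two carbocyclic amides, with a 2.6-fold lower number from compound 2 to compound 4 (0.42 log units; beyond the scatter) and a 2.8-fold lower number from compound 1 to compound 4 (0.45 log units; beyond the scatter), all modest steps that leave compound 4 lowest of the four. Whether this gain needs chlorine itself stays open: plain phenyl, 4-fluorophenyl and 4-methoxyphenyl are not among the compounds shown. Nothing at hand accounts for the difference between the two chlorophenyl groups.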